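Notes: 1H-imidazol-1-yl for phenyl in compound 1

The source may hold more compounds than are shown below. What is called first, only, known or untested is meant among the compounds shown, and "the series" means these compounds.

Compound 1 `CCN(c1cccc(-c2ccccc2)c1)c1ccc(C#N)c(Cl)c1` offers no number to start from: in a functional assay on VCaP cells (Homo sapiens) for antiproliferative activity, read by CCK-8 assay, with a stated time of 6 days (on this read-out higher numbers stand for weaker inhibition and lower numbers for stronger inhibition), compound 1 gives "not determined" (no result reported). Compound 2 `N#Cc1ccc(N2CCc3cc(-c4cncnc4)ccc32)cc1C(F)(F)F` likewise gives "not determined" (no result reported). Compound 3 `CCN(c1ccc(C#N)c(Cl)c1)c1cc(-c2ccccc2)ccc1C` gives > 30000 nM, which is a limit and not a number. Compound 4 `CCN(c1cccc(-n2ccnc2)c1)c1ccc(C#N)c(Cl)c1` comes from compound 1 by one change, (1H-imidazol-1-yl in place of phenyl on an aromatic carbon), with 1H-imidazol-1-yl in place of phenyl on an aromatic carbon. For the measured compounds named here, no measured step exists for this change. No step beyond the usual scatter is expected in this assay, and inhibition is expected to stay weak, going by the limit of compound 3 at > 30000 nM. For compound 4 the estimated value is 20000 nM, with an expected range of 5000 nM to 60000 nM.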

Compound 4, half-maximal inhibitory concentration: > 30000 nM
Compound 4 ended at the assay's limit; the forecaster's own chance of this, stated with the estimate: 55%; middle value at least 1.5-fold (0.17 log units) away from the limit.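

In this assay compound 4 gives > 30000 nM, which is a limit and not a number. Compound 1 gives no single number either, so no step can be read between compound 1 and compound 4. Still open, on these data alone, is whether 1H-imidazol-1-yl in place of phenyl changes inhibition in this assay at all.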